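Chain-end change on the fluoro parent of this series

The source may hold more compounds than are shown below. What is called first, only, known or untested is meant among the compounds shown, and "the series" means these compounds.

Measured compounds in a functional assay on MCF7 cells (Homo sapiens) for antiproliferative activity; on this read-out higher numbers stand for weaker inhibition and lower numbers for stronger inhibition:
- compound 1, `C#CCCCn1c(Cc2cc(OC)c(OC)c(OC)c2)nc2c(N)nc(F)nc21`, gives 11000 nM
- compound 2, `C#CCCCn1c(Cc2cc(OC)c(OC)c(OC)c2)nc2c(N)ncnc21`, gives 24000 nM
- compound 3, `COc1cc(Cc2nc3c(N)ncnc3n2CCCC(C)C)cc(OC)c1OC`, gives 69200 nM

Compound 1 gives the lowest number of the three. Its nearest neighbour is compound 2, with a step of a 2.2-fold higher number from compound 1 to compound 2 (0.34 log units; beyond the scatter); the furthest is compound 3, which sits beyond compound 2 by a step of a 2.9-fold higher number from compound 2 to compound 3 (0.46 log units; beyond the scatter).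

The unmeasured compound 4, `C=CCCn1c(Cc2cc(OC)c(OC)c(OC)c2)nc2c(N)nc(F)nc21`, differs from compound 1 by vinyl in place of propargyl on a saturated chain carbon, two bonds along the chain from an aromatic nitrogen. Going by the values given here, no measured step repeats this change. Among the compounds with values here, the only step touching the chain end is that from compound 2 to compound 3, where isopropyl in place of ethynyl gave a 2.9-fold higher number from compound 2 to compound 3 (0.46 log units; beyond the scatter), a modest loss. The change to compound 4 also removes the triple bond outside aromatic rings and shortens the chain, so a modest rise in the number is expected in this assay, smaller than the step to compound 3 and possibly within the scatter.

For compound 4 the expected value is 18000 nM, with a range from 8000 nM to 40000 nM, corresponding to an expected step of a 1.6-fold higher number from compound 1 to compound 4 (0.21 log units; within the scatter).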

Compound 4, half-maximal inhibitory concentration: 33100 nM
Compound 4: middle estimate off by 1.8-fold (0.26 log units), on the low side; the measured number falls inside the stated range.
By their numbers in this assay, from the lowest: compound 1; then compounds 2 and 4 (each within the scatter of the next); then compound 3.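

In this assay the change from propargyl to vinyl on the fluoro parent gives a 3.0-fold higher number from compound 1 to compound 4 (0.48 log units; beyond the scatter). Alongside a 2.9-fold higher number from compound 2 to compound 3 (0.46 log units; beyond the scatter), which was read on the parent without fluoro, this means that both chain-end replacements of the ethynyl group shown here raise the number. The change to compound 4 alters chain length and bond type at once, and no measurement at hand bears on why the number rises.

Still open, going by these compounds, is whether a fully saturated chain of the same length as but-3-en-1-yl, or a longer chain ending in a triple bond, would separate these two contributions. Also open, on these data alone, is how a nitrile or an amine at the chain end would read on the fluoro parent, and whether the fluoro step persists with the but-3-en-1-yl chain.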